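A few compounds are considered here, and "the series" means these few. Any claim that something is new, unique, unknown or untested is made for them only; others in the source may bear on it.

Measured compounds in a functional assay on HL-60 cells (Homo sapiens) for antiproliferative activity, read by XTT assay, with a stated time of 72 h; on this read-out higher numbers stand for weaker inhibition and lower numbers for stronger inhibition:
compound 1, `Cc1ncnc2c1c(-c1cc3ccccc3o1)cn2[C@@H]1O[C@H](CO)[C@@H](O)[C@H]1O`, > 20000 nM
compound 2, `Cc1ncnc2c1c(-c1ccoc1)cn2[C@@H]1O[C@H](CO)[C@@H](O)[C@H]1O`, > 15000 nM
compound 3, `Cc1nc(N)c2c(-c3ccoc3)cn([C@@H]3O[C@H](CO)[C@@H](O)[C@H]3O)c2n1`, > 20000 nM

Compound 1 gives > 20000 nM in this assay, which is a limit of the assay and not a number. Compound 2 gives > 15000 nM, again a limit rather than a number. Compound 3 likewise reaches only a limit, > 20000 nM. Compounds 1 and 2 differ in one place, (1-benzofuran-2-yl in place of furan-3-yl on an aromatic carbon), but the step that the two limits leave unreadable from compound 2 to compound 1 cannot be read because the limit of > 15000 nM in this assay, at which 1 of the 3 values shown sits, and the limit of > 20000 nM in this assay, at which 2 of the 3 values shown sit, are where all three values sit. Compound 3 differs from compound 2 in more than one place; the difference between the two cores is not broken down here.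

Compound 4, `Cc1nc(N)c2c(-c3cc4ccccc4o3)cn([C@@H]3O[C@H](CO)[C@@H](O)[C@H]3O)c2n1`, has not yet been measured. It stands to compound 3 as compound 1 stands to compound 2: the change is 1-benzofuran-2-yl in place of furan-3-yl on an aromatic carbon, made at the same place as before, so it is the same change. Because the limit of > 20000 nM in this assay, at which 2 of the 3 values shown sit, is where compound 3 sits, no numeric starting point exists for compound 4, and the earlier step gives no direction. The author therefore expects the step that the limit leaves unreadable from compound 3 to compound 4, meaning no readable shift from the limit. For compound 4 the estimate in this assay is 25000 nM, with a range expected from 8000 nM to 100000 nM, and most likely the assay will again report only a limit.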

Compound 4, half-maximal inhibitory concentration: > 20000 nM
Compound 4: only a limit was reported; the forecaster's own chance of this, stated with the estimate: 85%; the middle value is on the limit's open side.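

In this assay compound 4 gives > 20000 nM, which is a limit of the assay and not a number. Among these compounds, compound 3 also stands only at a limit, so the step between compound 3 and compound 4 cannot be read, and no new step emerges. The compounds shown leave open what numeric value any of them would have and whether 1-benzofuran-2-yl in place of furan-3-yl changes the read-out at all.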